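This account rests on a few compounds, and the source may have more. Where it says the series, first, only, none or still open, it means among the compounds named here.

Measured so far:
compound 1, `C=C(Br)C(=O)Nc1ccc(/C=C/C(=O)c2ccccc2)cc1`, gives 5000 nM in a functional assay on L1210 cells (Mus musculus) for antiproliferative activity, with a stated time of 48 h; on this read-out higher numbers stand for weaker inhibition and lower numbers for stronger inhibition
compound 2, `C=C(Br)C(=O)Nc1ccc(/C=C/C(=O)c2ccc(OC)cc2)cc1`, gives 980 nM in this assay
compound 3, `Nc1ccc(C(=O)/C=C/c2ccccc2)cc1`, gives 14000 nM in this assay

Compound 1 and compound 2 differ in one place, (methoxy in place of hydrogen on an aromatic carbon), and this change made a 5.1-fold lower number from compound 1 to compound 2 (0.71 log units; beyond the scatter). Compound 4, `COc1ccccc1/C=C/C(=O)c1ccc(N)cc1`, is not yet measured and relates to compound 3 through (methoxy in place of hydrogen on an aromatic carbon). The difference between the two cores, compound 1 against compound 3, is not broken down here. The two changes are the same kind of change rather than the same: in compound 2 the methoxy sits para to a large group, in compound 4 ortho to a large group. A lower number for compound 4 than for compound 3 is expected because the earlier step was a 5.1-fold lower number from compound 1 to compound 2 (0.71 log units; beyond the scatter). With the methoxy placed differently, the expected step is a more cautious a 2.0-fold lower number from compound 3 to compound 4 (0.30 log units; within the scatter). Compound 4 is therefore estimated at 7000 nM in this assay, most likely between 2500 nM and 20000 nM.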

Compound 4, half-maximal inhibitory concentration: 12000 nM
Compound 4: the middle estimate sits 1.7-fold (0.23 log units) below what was measured, and the stated range covers the measured number.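

In this assay, the methoxy step on the second core gave a 1.2-fold lower number from compound 3 to compound 4 (0.07 log units; within the scatter), so no effect of the change can be claimed on that core. The clear drop seen on the core of compound 1 therefore did not carry over at the same size: the same change on two cores in this assay, a 5.1-fold lower number (0.71 log units; beyond the scatter) from compound 1 to compound 2 and a 1.2-fold lower number (0.07 log units; within the scatter) from compound 3 to compound 4, 4.4-fold (0.64 log units) apart, beyond the scatter of two such steps This does not show whether the core or the place of the methoxy accounts for the gap, for the two steps differ in both and the data cannot separate them.

Going by these compounds, it remains open how a methoxy ortho to a large group would behave on the core of compound 1. On these data alone, whether a smaller group such as fluorine or a hydroxyl in that place would shift the number on either core is also open.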